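Methoxy added to the aryl group: compound 2 to compound 3

A few compounds are considered here, and "the series" means these few. Any claim that something is new, unique, unknown or untested is made for them only; others in the source may bear on it.

Measured compounds:
compound 1, `Cc1cc(O)c(C2=NN(c3ccc(S(N)(=O)=O)cc3)C(/C=C/c3ccccc3)C2)cc1Cl`, 92500 nM
compound 2, `COc1ccc(C2CC(c3cc(Cl)c(C)cc3O)=NN2c2ccc(S(N)(=O)=O)cc2)cc1OC`, 27400 nM

In a functional assay on HCC 2998 cells (Homo sapiens) for antiproliferative activity, with a stated time of 48 h (a lower number here means that less compound is tolerated, a higher number that more compound is tolerated), compound 1 gives 92500 nM, while compound 2 gives 27400 nM. Compound 2 therefore holds the lowest number of the two measured; its nearest neighbour is compound 1, and the step of a 3.4-fold lower number from compound 1 to compound 2 (0.53 log units; beyond the scatter) separates them. Among the compounds with values here, that step exchanges the whole group on the saturated ring carbon, 2-phenylethenyl for 3,4-dimethoxyphenyl, and is the only measured step.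

Compound 3, `COc1ccc(C2CC(c3cc(Cl)c(C)cc3O)=NN2c2ccc(S(N)(=O)=O)cc2)c(OC)c1OC`, differs from compound 2 by methoxy in place of hydrogen on an aromatic carbon. Within the data shown here, no measured step adds a methoxy to an aromatic carbon; the one step recorded, a 3.4-fold lower number from compound 1 to compound 2 (0.53 log units; beyond the scatter), concerns a change of a different kind and gives no guidance on the size or direction of this one. With nothing bearing on it, the working expectation is no step beyond the scatter in this assay, with a wide range to cover the lack of precedent. Compound 3 is estimated at 25000 nM, with a range from 9000 nM to 70000 nM. This estimate corresponds to an expected step of a 1.1-fold lower number from compound 2 to compound 3 (0.04 log units; within the scatter).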

Compound 3, concentration lethal to 50% of the cells: 7640 nM
The estimate for compound 3 lay 3.3-fold (0.51 log units) above the measured number, and the stated range ends above it.
By their numbers in this assay, from the lowest: compound 3; then compound 2; then compound 1.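

In this assay the aryl group on the saturated ring carbon responds to a change far smaller than the exchange of a whole group: methoxy in place of hydrogen, on the aromatic carbon ortho to a large group and ortho to a methoxy group, gives a 3.6-fold lower number from compound 2 to compound 3 (0.55 log units; beyond the scatter) and so is a step beyond the scatter. Before this result, the only comparison at this ring carbon was between 3,4-dimethoxyphenyl and 2-phenylethenyl, whereas 2,3,4-trimethoxyphenyl in place of 2-phenylethenyl now gives a 12-fold lower number from compound 1 to compound 3 (1.08 log units; beyond the scatter) as the largest step in the series, and the two aryl-bearing compounds show the number falling as a methoxy is added. Nothing available accounts for the size or direction of this step.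

On these data alone, it remains open whether the step belongs to methoxy itself or would also follow from a hydroxy, a fluorine or an ethoxy on the same aromatic carbon. Also open, as far as these compounds go, is whether 3,4,5-trimethoxyphenyl, which places the added methoxy on a different carbon of the ring, would give a step of similar size.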